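A few compounds are considered here, and "the series" means these few. Any claim that something is new, unique, unknown or untested is made for them only; others in the source may bear on it.

Of the compounds shown here, three have been measured in a functional assay; a higher number here means a weaker inhibitor, a lower number a stronger inhibitor.

Compound 1, `CC(C)=CCOc1ccc2c(c1)OC(c1ccccc1Br)CC2=O`: 3180 nM
Compound 2, `CC(C)=CCOc1ccc2c(c1)OC(c1cccc(Br)c1)CC2=O`: 5280 nM
Compound 3, `CC(C)=CCOc1cc(O)c2c(c1)OC(c1ccccc1Br)CC2=O`: 3820 nM

Compound 2 differs from compound 1 by a single change, (3-bromophenyl in place of 2-bromophenyl on a saturated ring carbon). That change gave a 1.7-fold higher number from compound 1 to compound 2 (0.22 log units; within the scatter). Compound 3 differs from compound 1 in its core, (hydroxy in place of hydrogen on an aromatic carbon), and that change gave a 1.2-fold higher number from compound 1 to compound 3 (0.08 log units; within the scatter). Compound 4, `CC(C)=CCOc1cc(O)c2c(c1)OC(c1cccc(Br)c1)CC2=O`, has not yet been measured in this assay. It differs from compound 3 by 3-bromophenyl in place of 2-bromophenyl on a saturated ring carbon, which is the same change that turned compound 1 into compound 2, made at the same place on the core of compound 3. Among the measured compounds shown here, only one earlier example of this change is known, and its step stayed within the scatter, so any expectation for compound 4 rests on a single pair of compounds. For compound 4 a step of about a 1.6-fold higher number from compound 3 to compound 4 (0.20 log units; within the scatter) is expected, because of a 1.7-fold higher number from compound 1 to compound 2 (0.22 log units; within the scatter). Compound 4 is therefore estimated at 6000 nM, most likely falling between 3000 nM and 12000 nM.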

Compound 4, half-maximal inhibitory concentration: 4040 nM
Compound 4: middle estimate off by 1.5-fold (0.17 log units), on the high side; low and high end bracket the measured number.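

In this assay, 3-bromophenyl in place of 2-bromophenyl on the core that carries the hydroxy gives a 1.1-fold higher number from compound 3 to compound 4 (0.02 log units; within the scatter), and hydroxy in place of hydrogen on the core that carries 3-bromophenyl gives a 1.3-fold lower number from compound 2 to compound 4 (0.12 log units; within the scatter). Set beside its earlier example, the bromine change looks the same on both cores: the same change on two cores in this assay, a 1.7-fold higher number (0.22 log units; within the scatter) from compound 1 to compound 2 and a 1.1-fold higher number (0.02 log units; within the scatter) from compound 3 to compound 4, 1.6-fold (0.20 log units) apart, within the scatter of two such steps. Among the compounds shown here, the hydroxy change also looks the same on both cores, but since every one of these steps stays within the scatter, the series shows only that neither change has a measurable effect on either core, not that a large effect would carry over from one core to another: the same change on two cores in this assay, a 1.2-fold higher number (0.08 log units; within the scatter) from compound 1 to compound 3 and a 1.3-fold lower number (0.12 log units; within the scatter) from compound 2 to compound 4, 1.6-fold (0.20 log units) apart, within the scatter of two such steps.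

Going by these compounds, it remains open whether a methoxy group, an amine or a carboxylic acid in place of the bromine would give a step beyond the scatter. On these data alone, it is also open whether such a step would keep its size when moved from one core to the other.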